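Urea in place of pyridyl amide on the proline nitrogen

The compounds below may be only part of what the source reports. "The series", "measured", "known", "first", "only" and "open" are said of these compounds alone.

Working notes. Among the measured compounds shown here, compound 2 `O=C([C@@H]1CCCN1C(=O)c1ccncc1)N1CCC(NS(=O)(=O)c2cc(S(=O)(=O)c3ccccc3)ccc2C(F)(F)F)CC1` gives 350 nM in a functional assay on U2OS cells for antagonist activity at proto-oncogene Wnt-3 (Homo sapiens), read by a luciferase reporter, with a stated time of 18 h (on this read-out lower numbers stand for an effect already at smaller amounts and higher numbers for an effect only at larger amounts of compound), the lower of the two numbers in hand; compound 1 `CN(C)c1ccc(C(=O)N2CCC[C@H]2C(=O)N2CCC(NS(=O)(=O)c3cc(S(=O)(=O)c4ccccc4)ccc3C(F)(F)F)CC2)cc1` gives 830 nM, and the only measured step is a 2.4-fold lower number from compound 1 to compound 2 (0.38 log units; beyond the scatter). Compound 3 `O=C([C@@H]1CCCN1C(=O)Nc1ccccc1)N1CCC(NS(=O)(=O)c2cc(S(=O)(=O)c3ccccc3)ccc2C(F)(F)F)CC1` carries anilino in place of pyridin-4-yl on a carbonyl carbon; the same difference, cut one bond further out, reads (pyridin-4-yl)carbonyl to phenylcarbamoyl. For the measured compounds named here, no measured step swaps an aryl for an anilino at this carbonyl, so the step from compound 1 to compound 2 bears on it only as a guide to size: a modest step in either direction is expected, a 1.6-fold higher number from compound 2 to compound 3 (0.20 log units; within the scatter). Compound 3 is estimated at 550 nM, range 150 nM to 2000 nM.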

Compound 3, half-maximal effective concentration: 310 nM
Compound 3: middle estimate off by 1.8-fold (0.25 log units), on the high side; low and high end bracket the measured number.
By their numbers in this assay, from the lowest: compounds 3 and 2 (each within the scatter of the next); then compound 1.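

In this assay, anilino is tolerated in place of pyridin-4-yl on this carbonyl carbon, with a 1.1-fold lower number from compound 2 to compound 3 (0.05 log units; within the scatter), so the urea and the pyridyl amide cannot be told apart here. The 4-(dimethylamino)phenyl group stands apart from the anilino group as well, with a 2.7-fold lower number from compound 1 to compound 3 (0.43 log units; beyond the scatter). No measured evidence bears on this result.

As far as these compounds go, whether the hydrogen on the anilino nitrogen matters remains open. So does whether an N-methylanilino group or a saturated amine such as piperidine on this carbonyl carbon would match compound 2 and compound 3.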